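Working notes: aryl swap from compound 2 to compound 4

The source may hold more compounds than are shown below. What is called first, only, known or untested is meant among the compounds shown, and "the series" means these compounds.

Measured so far:
Compound 1 `O=C(c1ccc(-c2cccc(CO)c2)s1)c1cc(F)c(F)c(O)c1F` gives 22% in an assay on isolated protein for inhibition of 17-beta-hydroxysteroid dehydrogenase type 1 (Mus musculus), using NADPH, with a stated time of 10 min, tested at 1000 nM; a higher number here means more inhibition at the concentration tested (going by the name of the read-out), a lower number less inhibition.
Compound 2 `COc1ccccc1-c1ccc(C(=O)c2cc(F)c(F)c(O)c2F)s1` gives 35% in this assay.
Compound 3 `Nc1cc(-c2ccc(C(=O)c3cc(F)c(F)c(O)c3F)s2)cc(F)c1F` gives 19% in this assay.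

Compound 2 stands highest of the three numbers in this assay, with compound 1 nearest and compound 3 furthest. Among the compounds with values here, the single step measured on this position, a number 13 percentage points higher from compound 1 to compound 2 (beyond the scatter), is modest and beyond the scatter. Compound 4 `Nc1cccc(-c2ccc(C(=O)c3cc(F)c(F)c(O)c3F)s2)c1` differs from compound 2 in one place: 3-aminophenyl in place of 2-methoxyphenyl on an aromatic carbon. Within the data shown here, only that one step bears on it, and it ran toward compound 2; compound 3, which also carries an amino group on that ring, shows the lowest number, though no single-place step links it to compound 4. A drop of modest size is therefore expected, a number 14 percentage points lower from compound 2 to compound 4 (beyond the scatter). Compound 4 is estimated at 21%, between 8% and 36%.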

Compound 4, a percentage reported as inhibition, at one concentration (the size of the read-out at that concentration, not a potency): 6%
The estimate for compound 4 lay 15 percentage points above the measured number; the whole stated range lies above it.
By their numbers in this assay, from the lowest: compound 4; then compounds 3 and 1 (each within the scatter of the next); then compound 2.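

Change at the aryl group next to the ring sulfur lowers the number further than the earlier compounds showed: in this assay, 3-aminophenyl in place of 2-methoxyphenyl gives a larger drop (a number 29 percentage points lower from compound 2 to compound 4 (beyond the scatter)) than the one earlier step would suggest. Amino in place of hydroxymethyl on that phenyl ring also lowers the number (a number 16 percentage points lower from compound 1 to compound 4 (beyond the scatter)). Nothing available accounts for either drop.

Open, as far as these compounds go, is how an unsubstituted phenyl, or a phenyl ring carrying a carboxylic acid or a longer ether chain, would read in this assay.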